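Methyl to dimethylamino at the assay limit

The source may hold more compounds than are shown below. What is called first, only, known or untested is meant among the compounds shown, and "the series" means these compounds.

In a functional assay on A549 cells (Homo sapiens) for inhibition (on this read-out higher numbers stand for weaker inhibition and lower numbers for stronger inhibition), compound 3 (`Cc1ccc(/C=C/c2ccc3ccccc3c2)cc1`) gives > 5000 nM, which is a limit and not a number. Compound 1 (`COc1ccc(/C=C/c2ccc3ccccc3c2)cc1`) gives > 5000 nM, also a limit. Compound 2 (`FC(F)(F)Oc1ccc(/C=C/c2ccc3ccccc3c2)cc1`) gives > 5000 nM, likewise a limit. The measurements thus offer only (the limit of > 5000 nM in this assay, at which 3 of the 3 values shown sit).

Compound 4 (`CN(C)c1ccc(/C=C/c2ccc3ccccc3c2)cc1`) carries dimethylamino in place of methyl on an aromatic carbon, para to a large group: dimethylamino in place of methyl on an aromatic carbon. Two measured swaps on that carbon bear on this: a step that the two limits leave unreadable from compound 1 to compound 3 and a step that the two limits leave unreadable from compound 2 to compound 3. The third, a step that the two limits leave unreadable from compound 1 to compound 2, is no more informative. With no size or direction to carry over, no clear step is expected. The expected change is a step that the limit leaves unreadable from compound 3 to compound 4. Compound 4 is estimated at 6000 nM, with an expected range of 2000 nM to 20000 nM.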

Compound 4, half-maximal inhibitory concentration: 3660 nM
Compound 4: the middle estimate sits 1.6-fold (0.21 log units) above what was measured; measured number inside the range.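

Of the groups shown on this aromatic carbon, only dimethylamino gives a number rather than a limit in this assay, while the steps among compound 1, compound 2 and compound 3 cannot be read: the limit of > 5000 nM in this assay, at which 3 of the 4 values shown sit.

The change gives an at least 1.3-fold lower number from compound 3 to compound 4 (0.13 log units; that floor lies within the scatter) and an at least 1.3-fold lower number from compound 2 to compound 4 (0.13 log units; that floor lies within the scatter) and an at least 1.3-fold lower number from compound 1 to compound 4 (0.13 log units; that floor lies within the scatter) as its readable steps. Each is only a floor within the usual scatter, so a real gain in inhibition is not established.

On these data alone, whether a plain amino group, a longer chain on the nitrogen or a carboxylic acid on this carbon would give a lower number stays open.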